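This account rests on a few compounds, and the source may have more. Where it says the series, first, only, none or still open, it means among the compounds named here.

Among the compounds with values here, in an ADME assay on A549 cells (Homo sapiens) for cytotoxicity, read by resazurin assay, with a stated time of 48 h (on this read-out higher numbers stand for lower toxicity in this test and lower numbers for higher toxicity in this test), compound 2 `CC(C)CNc1ccc(NC(=O)c2cc(Cl)ccc2O)c(Cl)c1` gives 60000 nM, the highest of the three numbers so far. Compound 1 `CC(C)Nc1ccc(NC(=O)c2cc(Cl)ccc2O)c(Cl)c1` gives 11000 nM and compound 3 `O=C(Nc1ccc(NCc2cc(Cl)cc(Cl)c2)cc1Cl)c1cc(Cl)ccc1O` gives 13300 nM in this assay. Compound 4 `CC(C)(CCO)Nc1ccc(NC(=O)c2cc(Cl)ccc2O)c(Cl)c1` differs from compound 2 by 3-hydroxy-1,1-dimethylpropyl in place of isobutyl on a nitrogen on an aromatic ring. Within the data shown here, the only steps that touch the same nitrogen are a 5.5-fold higher number from compound 1 to compound 2 (0.74 log units; beyond the scatter) and a 4.5-fold lower number from compound 2 to compound 3 (0.65 log units; beyond the scatter), so changes here have moved this assay by modest amounts in either direction; no measured step introduces a hydroxyl, so the direction for compound 4 is uncertain. A modest step is expected, a 2.0-fold lower number from compound 2 to compound 4 (0.30 log units; within the scatter), probably back toward the other two compounds. Compound 4 is therefore estimated at 30000 nM, with a range from 8000 nM to 100000 nM.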

Compound 4, half-maximal cytotoxic concentration: 170000 nM
For compound 4 the middle estimate is 5.7-fold (0.75 log units) below the measured one; measured number outside the range, above it.
By their numbers in this assay, from the lowest: compounds 1 and 3 (each within the scatter of the next); then compound 2; then compound 4.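

In this assay, within the data shown here, compound 4 now stands highest, which shows that the group on this nitrogen can raise the number further than the earlier compounds showed (in a 2.8-fold higher number from compound 2 to compound 4 (0.45 log units; beyond the scatter)) and that the gap to the other two is large (in a 13-fold higher number from compound 3 to compound 4 (1.11 log units; beyond the scatter)) and (in a 15-fold higher number from compound 1 to compound 4 (1.19 log units; beyond the scatter)). This is also the only group shown here that carries a hydroxyl, so the rise belongs to this one change and not yet to a pattern. Nothing measured here explains the rise.

Whether the hydroxyl or the 1,1-dimethyl branching accounts for it remains open. So does whether an amine or a carboxylic acid at the end of the chain would move the number in the same way.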